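The source may hold more compounds than are shown below. What is called first, only, known or untested is meant among the compounds shown, and "the series" means these compounds.

Compound 1 `N#CC1=C(NC(=O)/C=C/c2ccccc2)N(c2ccc(S(N)(=O)=O)cc2)C2=C(C(=O)CCC2)C1c1ccc(Cl)cc1Cl` gives 30% in a functional assay on Ehrlich cells (Mus musculus) for cytotoxicity, read by trypan blue exclusion, with a stated time of 2 h, tested at 25 ug/mL; on this read-out higher numbers stand for a stronger effect at the one concentration tested and lower numbers for a weaker effect. Compound 2 `CN(C)c1ccc(/C=N/C2=C(C#N)C(c3ccc(Cl)cc3Cl)C3=C(CCCC3=O)N2c2ccc(S(N)(=O)=O)cc2)cc1` gives 30% in this assay, and the step of no change at the digits printed from compound 1 to compound 2 (within the scatter) stays within the scatter, so compound 2 stands level with compound 1 at the digits shown. Compound 3 `CCO/C=N/C1=C(C#N)C(c2ccc(Cl)cc2Cl)C2=C(CCCC2=O)N1c1ccc(S(N)(=O)=O)cc1` differs from compound 2 by ethoxy in place of 4-(dimethylamino)phenyl on a carbon with a double bond to nitrogen. Among the measured compounds shown here, the only measured step, no change at the digits printed from compound 1 to compound 2 (within the scatter), swapped one group for another of the same size and moved nothing; an ethoxy at this place has no precedent here. The expectation for compound 3 is a step of no change at the digits printed from compound 2 to compound 3 (within the scatter) of no size beyond the scatter. Compound 3 is estimated at 30%, range 15% to 45%.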

Compound 3, a percentage reported as activity, at one concentration (the size of the read-out at that concentration, not a potency): 30%
For compound 3 middle estimate and measured number coincide at the digits printed, and the stated range covers the measured number.
By their numbers in this assay, from the lowest: compounds 1, 2 and 3 (each within the scatter of the next).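

In this assay, ethoxy in place of 4-(dimethylamino)phenyl on a carbon with a double bond to nitrogen gives no change at the digits printed from compound 2 to compound 3 (within the scatter), so a ring in this group is not required to hold the level seen so far. The ring-free group of compound 3, set against the larger ring-bearing group of compound 1, likewise gives no change at the digits printed from compound 1 to compound 3 (within the scatter). Nothing on hand explains this flat response. As far as these compounds go, whether any group at this place moves the read-out stays open, for instance a primary amine or a carboxylic acid. Comparison at other concentrations also stays open.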